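Replacing tert-butyl with methyl in compound 3

The source may hold more compounds than are shown below. What is called first, only, known or untested is meant among the compounds shown, and "the series" means these compounds.

Compound 1 (`COc1ncccc1/N=c1\c(O)c(O)\c1=N/C(C)(C)C`) gives 2560 nM in the test
Compound 2 (`CC(C)(C)/N=c1\c(O)c(O)\c1=N/c1cnc2ccccc2c1`) gives > 30000 nM in the test
Compound 3 (`CC(C)(C)/N=c1\c(O)c(O)\c1=N/c1ccc(C#N)cc1`) gives 560 nM in the test

All three compounds were tested in a functional assay for inhibition, with Rattus norvegicus as the target (a lower number here means a stronger inhibitor, a higher number a weaker inhibitor), as a half-maximal inhibitory concentration. For compound 2 the entry > 30000 nM is a limit and not a number. That leaves two numbers to compare. Compound 3 at 560 nM has the lower of them and is the stronger inhibitor of that pair, while compound 1 at 2560 nM lies higher by a gap beyond the usual scatter.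

Compound 4 (`C/N=c1\c(O)c(O)\c1=N/c1ccc(C#N)cc1`) has not yet been measured. It differs from compound 3 in one place, with methyl in place of tert-butyl on a double-bonded nitrogen. All three measured compounds carry tert-butyl, so the data hold no direct test of this change and any forecast is uncertain. Starting from compound 3 at 560 nM a weaker result is expected in this assay rather than no change beyond the scatter. The expected change is a 5.4-fold higher number from compound 3 to compound 4 (0.73 log units; beyond the scatter) and it is estimated to lie beyond the scatter. The estimated value for compound 4 is 3000 nM with an expected range from 800 nM to 15000 nM as its span.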

Compound 4, half-maximal inhibitory concentration: > 30000 nM
Compound 4: no number, only a limit; the forecaster's own chance of this, stated with the estimate: 12%; at least 10-fold (1.00 log units) between middle value and limit.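

Until now every measured compound carried tert-butyl, so the series gave no view of this position; the first change made there shows that it matters strongly in this assay, with methyl in place of tert-butyl on a double-bonded nitrogen giving an at least 53-fold higher number from compound 3 to compound 4 (1.72 log units; beyond the scatter). In this assay compound 4 gives > 30000 nM, which is a limit and not a number. The step therefore marks a minimum loss of inhibition rather than a measured size, and compound 4 shares this limit with one other compound: the limit of > 30000 nM in this assay, at which 2 of the 4 values shown sit.

The compounds shown leave open where between methyl and tert-butyl the inhibition falls away, which ethyl or isopropyl on this nitrogen would help to settle, and whether a longer chain or a cyclohexyl group could match tert-butyl. They also leave open whether methyl in place of tert-butyl would cost as much in the setting of compound 1, since this change has been read only once, from compound 3.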